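The compounds below may be only part of what the source reports. "The series", "measured", "known", "first", "only" and "open" are said of these compounds alone.

Working notes on a small set of acylthioureas sharing one core.

Compound 1 `O=C(NC(=S)Nc1nc2ccccc2s1)c1ccccc1`, compound 3 `O=C(NC(=S)Nc1nc2ccccc2s1)c1ccc([N+](=O)[O-])cc1` and compound 2 `O=C(NC(=S)Nc1nc2cc(Br)ccc2s1)c1ccc([N+](=O)[O-])cc1` have been measured in a functional assay on HeLa cells (Homo sapiens) for cytotoxicity, read by MTT assay, with a stated time of 24 h; a higher number here means a weaker inhibitor, a lower number a stronger inhibitor. Compound 1 gives 57500 nM. Compound 3 gives 62600 nM. Compound 2 gives 56500 nM. All three numbers lie within the usual scatter of one another, so no order among them is claimed and none of the three is called stronger or weaker than another.

Two single-point changes connect the measured compounds. The step of a 1.1-fold lower number from compound 3 to compound 1 (0.04 log units; within the scatter) goes with the change (hydrogen in place of nitro on an aromatic carbon). The step of a 1.1-fold higher number from compound 2 to compound 3 (0.04 log units; within the scatter) goes with the difference between the two cores, which is bromo in place of hydrogen on an aromatic carbon.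

Compound 4 `O=C(NC(=S)Nc1nc2cc(Br)ccc2s1)c1ccccc1` has not been measured. It differs from compound 2 by hydrogen in place of nitro on an aromatic carbon. Going by the values given here, this is the same change as the one from compound 3 to compound 1, made on the core of compound 2 instead of the core of compound 3; the surroundings of the place are described in the same words in both cases. The change occurs twice among the four compounds, once measured and once not.

Because a 1.1-fold lower number from compound 3 to compound 1 (0.04 log units; within the scatter) lies within the scatter, a step of similar size is expected here, a 1.0-fold lower number from compound 2 to compound 4 (0.02 log units; within the scatter). Among the compounds with values here, nothing among the measured compounds points to the core of compound 2 responding differently to this change than the core of compound 3. In this assay compound 4 is therefore expected to give about 54000 nM, with the likely range estimated from 30000 nM to 100000 nM.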

Compound 4, half-maximal inhibitory concentration: 64600 nM
For compound 4 the middle estimate is 1.2-fold (0.08 log units) below the measured one; the measured number falls inside the stated range.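

In this assay, hydrogen in place of nitro on the core of compound 2 gives a 1.1-fold higher number from compound 2 to compound 4 (0.06 log units; within the scatter), and this step does not differ from the one seen on the other core: the same change on two cores in this assay, a 1.1-fold lower number (0.04 log units; within the scatter) from compound 3 to compound 1 and a 1.1-fold higher number (0.06 log units; within the scatter) from compound 2 to compound 4, 1.2-fold (0.10 log units) apart, within the scatter of two such steps. Bromo in place of hydrogen, read on the compounds without nitro, gives a 1.1-fold higher number from compound 1 to compound 4 (0.05 log units; within the scatter), and it also agrees with its counterpart: the same change on two cores in this assay, a 1.1-fold higher number (0.04 log units; within the scatter) from compound 2 to compound 3 and a 1.1-fold lower number (0.05 log units; within the scatter) from compound 4 to compound 1, 1.2-fold (0.10 log units) apart, within the scatter of two such steps. Going by these compounds alone, each change therefore carries between these two cores without a detectable difference, but every step here lies within the scatter, so this shows only that neither change moves the number measurably on either core, not that a change with a step beyond the scatter would carry in the same way, nor that either change would behave alike on any further core.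

Still open, from the compounds shown here alone, is whether any other group at the place held by nitro, such as an amine, a carboxylic acid or a methoxy group, would give a step beyond the scatter in this assay. Equally open, going by these compounds, is whether chlorine, a methyl group or a longer chain at the place held by bromo would do so, and whether two such changes would then combine as independently as these two appear to.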